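Capping the Free Amine of Compound 2 with an Aminoacyl Group

The compounds below may be only part of what the source reports. "The series", "measured", "known", "first", "only" and "open" are said of these compounds alone.

Measured compounds:
compound 1 `CC(C)C[C@H](N)c1cc(C(F)(F)F)ccc1N1CCN(C(=O)[C@H]2CSC[C@@H]2c2ccc(Cl)cc2)CC1` — 280 nM
compound 2 `CC(C)C[C@H](N)c1cc(C(F)(F)F)ccc1N1CCN(C(=O)C2C(=O)OCC2c2ccc(Cl)cc2)CC1` — 260 nM

In an assay on HEK293 cells for displacement of a labelled ligand from Melanocortin receptor 4 (Homo sapiens) (on this read-out higher numbers stand for weaker inhibition and lower numbers for stronger inhibition), compound 2 gives 260 nM. Compound 1 gives 280 nM in this assay. Compound 2 holds the lower of the two numbers, but compound 1 sits so close that the gap lies within the scatter, so the two compounds cannot be told apart on these values. Going by the values given here, the cores of the two differ only in the ring that carries the chlorophenyl group, and no single-point step between measured compounds is available.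

Compound 3 `CC(C)C[C@H](NC(=O)CCN)c1cc(C(F)(F)F)ccc1N1CCN(C(=O)C2C(=O)OCC2c2ccc(Cl)cc2)CC1` is drawn from compound 2 by one change: (2-aminoethyl)carbonyl in place of hydrogen on an amine nitrogen. The primary amine of compound 2 becomes an amide bearing an amine of its own, two carbons further out. Among the compounds with values here, nothing among the measured compounds shows what replacing a hydrogen on this amine nitrogen does, so the expectation rests on the change alone. The step from compound 2 to compound 3 is expected to be a modest weakening, a 2.3-fold higher number from compound 2 to compound 3 (0.36 log units; beyond the scatter), of a size that would just clear the scatter. Compound 3 is therefore estimated at 600 nM in this assay, with a range from 150 nM to 2500 nM.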

Compound 3, inhibition constant: 180 nM
For compound 3 the middle estimate is 3.3-fold (0.52 log units) above the measured one; the range from low to high includes it.
By their numbers in this assay, from the lowest: compounds 3, 2 and 1 (each within the scatter of the next).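

In this assay, going by these compounds alone, the step is a 1.4-fold lower number from compound 2 to compound 3 (0.16 log units; within the scatter), the first reading of any change at this position. It shows that the hydrogen on this amine nitrogen can give way to (2-aminoethyl)carbonyl, a group of 5 heavy atoms with no ring, without any shift that can be told from the scatter, so the nitrogen need not stay a free primary amine for binding to remain in this range. Nothing measured here bears on why the added group leaves the value in this range.

Compound 3 still carries an amine at the far end of the new chain, so the compounds shown leave open whether any amine is needed at all: an acetyl group on the same nitrogen, which ends in no amine, would address that, while a longer chain such as (3-aminopropyl)carbonyl or a chain ending in a carboxylic acid would test how much the chain's length and end group matter. On these data alone, it also remains open whether (2-aminoethyl)carbonyl would behave the same way on the core of compound 1.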